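The source may hold more compounds than are shown below. What is called first, only, known or untested is meant among the compounds shown, and "the series" means these compounds.

Of the compounds shown here, three sharing one core have been tested in a functional assay on the whole organism (strain Wistar) with Rattus norvegicus as the target, read by paw edema; a lower number here means that less compound is needed, a higher number that more compound is needed for the effect. Compound 1 `CCC(=O)NS(=O)(=O)c1ccc(-n2nc(C(F)(F)F)cc2-c2ccc(Br)cc2)cc1COC(=O)CC` gives 12.5 mg/kg. Compound 2 `CCC(=O)NS(=O)(=O)c1ccc(-n2nc(C(F)(F)F)cc2-c2ccc(Br)cc2)cc1CO` gives 7.2 mg/kg, and compound 3 `CCC(=O)NS(=O)(=O)c1ccc(-n2nc(C(F)F)cc2-c2ccc(Br)cc2)cc1CO` gives 5.6 mg/kg. Compound 2 holds the second highest of the three numbers; its nearest neighbour is compound 3, with a 1.3-fold lower number from compound 2 to compound 3 (0.11 log units; within the scatter), and the other step, a 1.7-fold lower number from compound 1 to compound 2 (0.24 log units; within the scatter), also stays within the scatter.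

The step followed here leads from compound 2 to compound 4 `CCC(=O)NS(=O)(=O)c1ccc(-n2nc(C(F)(F)F)cc2-c2ccc3c(c2)CCO3)cc1CO`, not yet measured in this assay. The change is a group of 9 heavy atoms (8 carbon, 1 oxygen; one five-membered non-aromatic ring with 1 hetero atom, one six-membered aromatic ring of carbon only) in place of a group of 7 heavy atoms (6 carbon, 1 bromine; one six-membered aromatic ring of carbon only), on an aromatic carbon. Neither measured step touches this part of the molecule: one puts hydrogen in place of propanoyl on an oxygen on a saturated carbon, the other puts hydrogen in place of fluoro, and both were within the scatter. For the measured compounds named here, no measured step therefore bears on the exchange in compound 4, and nothing in the numbers points to a move beyond the scatter in either direction.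

The number expected for compound 4 in this assay is 7.5 mg/kg, with a range from 3.5 mg/kg to 16 mg/kg. This estimate means a 1.0-fold higher number from compound 2 to compound 4 (0.02 log units; within the scatter), a step expected to stay within the scatter.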

Compound 4, dose for half-maximal effect: 7.5 mg/kg
Beside the measured number, compound 4's estimate shows no gap at the digits printed, within the range that was stated.
By their numbers in this assay, from the lowest: compounds 3, 2, 4 and 1 (each within the scatter of the next, the first and the last beyond it).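

In this assay, the 4-bromophenyl group on the aromatic carbon next to the ring nitrogen can be exchanged for a group carrying a five-membered non-aromatic ring and one hydrogen-bond acceptor, and the number barely moves (a 1.0-fold higher number from compound 2 to compound 4 (0.02 log units; within the scatter)). For the compounds shown here, the earlier steps touched other parts of the molecule, so only this step shows that, in this one exchange, the bromine is not needed to keep the dose within the scatter. The data shown offer no measurement that would explain why the two groups read alike.

As far as these compounds go, whether other groups at this place, such as an unsubstituted phenyl, a pyridine or a benzoic acid, would also hold the number stays open. From the compounds shown here alone, it is equally open whether the same exchange would read alike with the difluoromethyl group of compound 3 on the core.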